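Swapping a Tolylsulfonyl Group for a Benzylsulfonyl Group

A few compounds are considered here, and "the series" means these few. Any claim that something is new, unique, unknown or untested is made for them only; others in the source may bear on it.

Going by the values given here, compound 1 `O=C(Nc1ccccc1)N1CCC(CN(Cc2ccc(Cl)cc2)Cc2ccc([N+](=O)[O-])s2)C1` is the only member of this small series with a number: in a functional assay on HEK293 cells for agonist activity at nuclear receptor subfamily 1 group D member 1 (Homo sapiens), read by a luciferase reporter, with a stated time of 24 h (on this read-out higher numbers stand for an effect only at larger amounts of compound and lower numbers for an effect already at smaller amounts), compound 1 gives 620 nM. Compound 2 `Cc1ccc(S(=O)(=O)N2CCC(CN(Cc3ccc(Cl)cc3)Cc3ccc([N+](=O)[O-])s3)C2)cc1` shares the core of compound 1 but was not measured: in this assay compound 2 gives "not determined" (no result reported), so no result is known for compound 2. Compound 3 `O=[N+]([O-])c1ccc(CN(Cc2ccc(Cl)cc2)CC2CCN(S(=O)(=O)Cc3ccccc3)C2)s1` differs from compound 2 only by benzyl in place of 4-methylphenyl on a sulfonyl sulfur. Among the compounds with values here, with no measured step between compounds to lean on, this change is expected to move the result by no more than the usual scatter, and its direction cannot be called. Compound 3 is therefore estimated to give 800 nM in this assay, most likely between 200 nM and 3200 nM.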

Compound 3, half-maximal effective concentration: 630 nM
The estimate for compound 3 lay 1.3-fold (0.10 log units) above the measured number; low and high end bracket the measured number.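

In this assay, benzylsulfonyl in place of phenylcarbamoyl on an amine nitrogen in a ring gives a 1.0-fold higher number from compound 1 to compound 3 (0.01 log units; within the scatter), so this position holds two quite different groups with no difference beyond the scatter. The swap of 4-methylphenyl for benzyl on the sulfonyl sulfur cannot itself be read, as compound 2 has no number. No measurement shown accounts for this match. From the compounds shown here alone, whether a longer chain, such as phenylethyl, or a carboxylic acid on the sulfonyl group would keep the result in this range remains open.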